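Replacing the Aryl Ring on the Chain of Compound 3

The source may hold more compounds than are shown below. What is called first, only, known or untested is meant among the compounds shown, and "the series" means these compounds.

Three measured compounds share one core and differ only in the ring attached to the chain. In a functional assay on HeLa cells (Homo sapiens) for cytotoxicity, read by MTT assay, with a stated time of 72 h (on this read-out lower numbers stand for stronger inhibition and higher numbers for weaker inhibition), compound 1 `COc1ccc(/C=C/C(=O)Nc2cc(C(=O)c3cc(OC)c(OC)c(OC)c3)ccc2OC)cc1` gives 10700 nM, compound 2 `C#CCOc1cccc(/C=C/C(=O)Nc2cc(C(=O)c3cc(OC)c(OC)c(OC)c3)ccc2OC)c1` gives 14000 nM, and compound 3 `COc1ccc(/C=C/C(=O)Nc2cc(C(=O)c3cc(OC)c(OC)c(OC)c3)cc(OC)c2OC)cc1N` gives 15800 nM. Compound 3 holds the highest of these three numbers, yet its gaps to compound 1 and compound 2 both lie within the scatter. Compound 4 `COc1cc(C(=O)c2cc(OC)c(OC)c(OC)c2)cc(NC(=O)/C=C/c2cc(F)c(F)c(F)c2)c1OC` differs from compound 3 by 3,4,5-trifluorophenyl in place of 3-amino-4-methoxyphenyl on a double-bonded chain carbon bound to a double-bonded chain carbon. Within the data shown here, the only measured step that exchanges a ring at this place is a 1.3-fold higher number from compound 1 to compound 2 (0.12 log units; within the scatter), which stayed within the scatter. Among the measured compounds shown here, no measured pair covers the exchange of 3-amino-4-methoxyphenyl for 3,4,5-trifluorophenyl itself, so guidance is loose. The expectation for compound 4 is therefore a step of a 1.1-fold lower number from compound 3 to compound 4 (0.02 log units; within the scatter), nothing beyond the scatter, giving an estimated 15000 nM with a range from 5000 nM to 45000 nM.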

Compound 4, half-maximal inhibitory concentration: 5000 nM
Estimate against measurement, compound 4: 3.0-fold (0.48 log units) above; low and high end bracket the measured number.
By their numbers in this assay, from the lowest: compound 4; then compounds 1, 2 and 3 (each within the scatter of the next).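

Among these compounds, the step of a 3.2-fold lower number from compound 3 to compound 4 (0.50 log units; beyond the scatter) in this assay is the first ring exchange at this place on the chain to pass beyond the scatter, so the ring here can change the number. The entering 3,4,5-trifluorophenyl has 0 hydrogen-bond donors and 0 hydrogen-bond acceptors, so the donor and acceptors of 3-amino-4-methoxyphenyl are not required for this level of activity. Nothing measured here explains the step. On these data alone, whether all three fluorines are needed remains open, since no ring with one or two fluorines appears. As far as these compounds go, how a chlorine or a nitrile on this ring would compare also remains open.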